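Chloro for methyl on the aminophenyl ring

The source may hold more compounds than are shown below. What is called first, only, known or untested is meant among the compounds shown, and "the series" means these compounds.

Measured so far:
compound 1 `COC(=O)c1c(Nc2ccccc2)sc(C(=O)c2ccc(C)cc2)c1C` — 3.16%
compound 2 `COC(=O)c1c(Nc2ccc(C)cc2)sc(C(=O)c2ccc(C)cc2)c1C` — "not active" (no number reported), without a number

In a functional assay, with a stated time of 150 min, tested at 10 ug/mL (on this read-out lower numbers stand for a weaker effect and higher numbers for a stronger effect at the one concentration tested), compound 1 gives 3.16%. In this assay compound 2 is reported as "not active" (no number reported), so no number places it; both results sit at the weak end. Compound 3 `COC(=O)c1c(Nc2ccc(Cl)cc2)sc(C(=O)c2ccc(C)cc2)c1C` differs from compound 2 by chloro in place of methyl on an aromatic carbon. Within the data shown here, no measured pair shows this change, so its effect is unknown; with compound 1 and compound 2 both weak, compound 3 is expected to stay low, any shift likely within the scatter. The estimate for compound 3 in this assay is 4%, ranging from 0% to 14%.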

Compound 3, a percentage reported as activity, at one concentration (the size of the read-out at that concentration, not a potency): "not active" (no number reported)
Compound 3: no number reported, so the estimate cannot be set against anything.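

In this assay, among these compounds, compound 2 and compound 3 are both reported as not active without a number, so no step between them can be read, and no evidence bears on this result. As far as these compounds go, whether chloro in place of methyl changes the effect at all stays open.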